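The source may hold more compounds than are shown below. What is called first, only, known or untested is meant among the compounds shown, and "the series" means these compounds.

Compound 1 `O=S(=O)(/C=C/c1ccc(Cl)cc1Cl)Cc1ccc(Nc2ncnc3ccccc23)cc1` gives 14000 nM in a functional assay on SW-620 cells (Homo sapiens); on this read-out higher numbers stand for weaker inhibition of growth and lower numbers for stronger inhibition of growth.
Compound 2 `O=S(=O)(/C=C/c1ccc(C(F)(F)F)cc1F)Cc1ccc(Nc2ncnc3ccccc23)cc1` gives 100000 nM in this assay.
Compound 3 `O=S(=O)(/C=C/c1ccc(Cl)cc1Cl)Cc1ccc(Nc2ncnc3ccc(Br)cc23)cc1` reaches only a limit of this assay, > 100000 nM, and no number.

All three compounds share a core in which a sulfonyl-linked chain carries an aryl group on a double bond. Compound 2 differs from compound 1 by 2-fluoro-4-(trifluoromethyl)phenyl in place of 2,4-dichlorophenyl on a double-bonded chain carbon bound to a double-bonded chain carbon, and this change gives a 7.1-fold higher number from compound 1 to compound 2 (0.85 log units; beyond the scatter). Compound 3 differs from compound 1 by bromo in place of hydrogen on an aromatic carbon, which gives an at least 7.1-fold higher number from compound 1 to compound 3 (0.85 log units; beyond the scatter); since compound 3 sits at the limit (the limit of > 100000 nM in this assay, at which 1 of the 3 values shown sits), only the lower bound of that step is known.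

Compound 4 `O=S(=O)(/C=C/c1ccc(C(F)(F)F)cc1F)Cc1ccc(Nc2ncnc3ccc(Br)cc23)cc1` has not yet been measured. It differs from compound 3 by 2-fluoro-4-(trifluoromethyl)phenyl in place of 2,4-dichlorophenyl on a double-bonded chain carbon bound to a double-bonded chain carbon, and the place of this change is the same as in the step from compound 1 to compound 2, so it is the same change, now made on the bromo-bearing core. Starting from compound 3, which is already at the limit, the step from compound 3 to compound 4 is expected to be a step that the limit leaves unreadable from compound 3 to compound 4, set beside the measured 7.1-fold higher number from compound 1 to compound 2 (0.85 log units; beyond the scatter); this rests on the direction of that measured step and on the limit of > 100000 nM in this assay, at which 1 of the 3 values shown sits, at which compound 3 stands. Compound 4 is therefore expected to give about 400000 nM in this assay, most likely reported only as a limit, with a plausible range of 100000 nM to 2000000 nM.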

Compound 4, concentration for 50% growth inhibition: 55000 nM
For compound 4 the middle estimate is 7.3-fold (0.86 log units) above the measured one, and the stated range ends above it.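

In this assay, the swap of 2,4-dichlorophenyl for 2-fluoro-4-(trifluoromethyl)phenyl does not carry over unchanged from the core of compound 1 to the bromo-bearing core, where it gives an at least 1.8-fold lower number from compound 3 to compound 4 (0.25 log units; that floor lies within the scatter), and the two steps differ: the same change on two cores in this assay, a 7.1-fold higher number (0.85 log units; beyond the scatter) from compound 1 to compound 2 and an at least 1.8-fold lower number (0.25 log units; that floor lies within the scatter) from compound 3 to compound 4, at least 12-fold (1.11 log units) apart, beyond the scatter of two such steps

The bromo change, seen from the other side of the same four compounds, gives a 1.8-fold lower number from compound 2 to compound 4 (0.26 log units; within the scatter), so it too depends on which aryl group the compound carries: the same change on two cores in this assay, an at least 7.1-fold higher number (0.85 log units; beyond the scatter) from compound 1 to compound 3 and a 1.8-fold lower number (0.26 log units; within the scatter) from compound 2 to compound 4, at least 12-fold (1.11 log units) apart, beyond the scatter of two such steps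

Compound 3 is recorded only as a limit, > 100000 nM, so these data do not show how large its step to compound 4 really is, whether the swap truly strengthens growth inhibition on the bromo-bearing core, or why the two cores behave differently.

With only two aryl groups and two cores shown, it remains open whether this dependence holds for any other pair of changes in the series. A methoxy group or an amine in place of the bromo, or a nitrile or a carboxylic acid on the aryl ring, could show whether the dependence is specific to these groups.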